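The source may report more compounds than this note shows. Statements on the series, on what has been measured and on what is new or still open speak of the compounds shown alone.

Measured compounds:
Compound 1, `C[C@@H]1CC(=O)N(c2ccccc2C(=O)OC[C@@H]2CCCN(CCCc3ccccc3)C2)C1=O`: 8910 nM
Compound 2, `COc1ccc(OCCCCCN2CCCC(COC(=O)c3ccccc3-c3ccccc3)C2)cc1`: 14500 nM

Both compounds were tested in an in vitro functional assay on HEK ts201 cells for antagonist activity at Neuronal acetylcholine receptor; alpha4/beta2 (Homo sapiens), read by fluorescence and calcium flux; on this read-out higher numbers stand for weaker inhibition and lower numbers for stronger inhibition. In this assay compound 1 gives 8910 nM; compound 2 gives 14500 nM. Compound 1 has the lower of the two numbers, but the gap to compound 2 lies within the usual scatter, so the two cannot be told apart on potency, and both sit at the weak end of what this assay reports.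

The next compound, compound 3, is `C[C@H]1CC(=O)N(c2ccccc2C(=O)OC[C@H]2CCCN(CCCc3ccccc3)C2)C1=O`. Compared with compound 1, (the two compounds have the same atoms and bonds and differ only in configuration as drawn: 2 of 2 stereo elements differ (all stereocentres are inverted: mirror images); a stereocentre at a saturated ring carbon is drawn R in compound 1 and S in compound 3; a stereocentre at a saturated ring carbon is drawn R in compound 1 and S in compound 3). In plain words, compound 3 is the mirror image of compound 1 with nothing added and nothing removed. Among the measured compounds no pair differs only in configuration, so there is no measured step to say how much a mirror image shifts the number here. Mirror-image pairs can read the same or differ widely, and without a guide the cautious expectation is a shift not clearly beyond the scatter, leaning toward no gain. The expected step is a 1.3-fold higher number from compound 1 to compound 3 (0.13 log units; within the scatter). For compound 3 the estimate is 12000 nM, with a range from 3000 nM to 50000 nM.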

Compound 3, half-maximal inhibitory concentration: 10500 nM
Estimate against measurement, compound 3: 1.1-fold (0.06 log units) above; measured number inside the range.
By their numbers in this assay, from the lowest: compounds 1, 3 and 2 (each within the scatter of the next).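

In this assay, inverting both stereocentres gives a 1.2-fold higher number from compound 1 to compound 3 (0.07 log units; within the scatter), so the two mirror images cannot be told apart on this read-out. Compounds 1 and 2 differ in more than one place, so they could say nothing about handedness, whereas this pair isolates it, and the comparison can be read directly because a single kind of difference separates the two structures: the fact that compounds 1 and 3 differ only in the configuration as drawn. At this weak end of the read-out, then, swapping the whole drawn configuration for its mirror image leaves the number within the usual scatter, which is a statement about this one pair and not a rule for the series.

On these data alone, both stereocentres change together here, so the effect of each one alone stays open, and two separate effects that happen to cancel would look the same as no effect at all. As far as these compounds go, it also stays open whether a change of group rather than of configuration, such as an amide in place of the ester, would move the number clearly away from the values seen so far.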